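Thiazole for Bromothiophene on a Bicyclic Amine: Cytotoxicity Outlook

This account rests on a few compounds, and the source may have more. Where it says the series, first, only, none or still open, it means among the compounds named here.

Compound 3 `C[C@H]1[C@H](NCc2sccc2Br)C[C@H]2C[C@@H]1C2(C)C` gives 50000 nM in an ADME assay on MDCK cells (Canis lupus familiaris) for cytotoxicity, read by microscopy, with a stated time of 48 h (on this read-out lower numbers stand for higher toxicity in this test and higher numbers for lower toxicity in this test), the highest of the two numbers shown. Its nearest neighbour, compound 1 `Cc1ccc(CN[C@@H]2C[C@H]3C[C@@H]([C@H]2C)C3(C)C)s1`, gives 780 nM. Compound 2 `C[C@H]1[C@H](NCc2cnccn2)C[C@H]2C[C@@H]1C2(C)C` returns only the limit > 100000 nM, which is not a number (the limit of > 100000 nM in this assay, at which 1 of the 3 values shown sits). The heteroaryl swaps on the saturated chain carbon bound to the amine nitrogen were large, an at least 120-fold higher number from compound 1 to compound 2 (2.10 log units; beyond the scatter) and a 64-fold higher number from compound 1 to compound 3 (1.81 log units; beyond the scatter), whereas an at least 2.0-fold lower number from compound 2 to compound 3 (0.30 log units; that floor lies within the scatter) stayed within the scatter. Compound 4 `Cc1csc(CN[C@@H]2C[C@H]3C[C@@H]([C@H]2C)C3(C)C)n1` differs from compound 3 by 4-methyl-1,3-thiazol-2-yl in place of 3-bromothiophen-2-yl on a saturated chain carbon bound to an amine nitrogen. The entering ring contains nitrogen, as does the pyrazin-2-yl of compound 2, so a small upward move or none beyond the scatter is expected. Compound 4 is therefore expected to give 60000 nM, between 15000 nM and 100000 nM, a step of a 1.2-fold higher number from compound 3 to compound 4 (0.08 log units; within the scatter).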

Compound 4, minimum cytotoxic concentration: > 100000 nM
Compound 4: only a limit was reported; the forecaster's own chance of this, stated with the estimate: 30%; middle value at least 1.6-fold (0.22 log units) from the limit.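

Compound 4 gives a limit, not a number: the limit of > 100000 nM in this assay, at which 2 of the 4 values shown sit. At this saturated chain carbon bound to an amine nitrogen, 4-methyl-1,3-thiazol-2-yl gives an at least 120-fold higher number from compound 1 to compound 4 (2.10 log units; beyond the scatter), while the change from 3-bromothiophen-2-yl gives an at least 2.0-fold higher number from compound 3 to compound 4 (0.30 log units; that floor lies within the scatter). Among these compounds, the two rings containing nitrogen, in compound 2 and compound 4, now both sit at the limit, and only the thiophene rings of compound 1 and compound 3 give numbers.

The step from compound 2 to compound 4 cannot be read. Going by these compounds, whether a phenyl ring, or a ring carrying a carboxylic acid, would also reach the limit at this place stays open.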